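The compounds below may be only part of what the source reports. "The series", "measured", "known", "first", "only" and "open" are said of these compounds alone.

Compound 1 `CC(C)N(Cc1cccc(OCCCCCC(=O)O)c1)C(=O)c1ccc(-c2cccc3ccccc23)cc1` in an ADME assay on BJ cells (Homo sapiens) for cytotoxicity, read by CellTiter-Glo and resazurin assay, with a stated time of 72 h (a lower number here means that less compound is needed, a higher number that more compound is needed for the effect), reads < 1.3 nM as a limit
Compound 2 `CC(=O)Nc1cccc(-c2ccc(C(=O)N(Cc3cccc(OCCCCCC(=O)O)c3)C(C)C)cc2)c1` reads > 26000 nM as a limit
Compound 3 `CC(C)N(Cc1cccc(OCCCCCC(=O)O)c1)C(=O)c1ccc(-c2cccc(-c3ccccc3)c2)cc1` reads > 26000 nM as a limit

Among the compounds with values here, compound 2 stands at a limit and not at a number, shared with compound 3: the limit of > 26000 nM in this assay, at which 2 of the 3 values shown sit, is the only evidence on its position. The change to compound 4 (`CC(=O)c1cccc(-c2ccc(C(=O)N(Cc3cccc(OCCCCCC(=O)O)c3)C(C)C)cc2)c1`) is acetyl in place of acetamido on an aromatic carbon with acetyl in place of acetamido on an aromatic carbon, meta to a large group.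

The nearest measured step is a step that the two limits leave unreadable from compound 2 to compound 3 and it gives no size. Replacing naphthalen-1-yl gave an at least 20000-fold higher number from compound 1 to compound 2 (4.30 log units; beyond the scatter) and also an at least 20000-fold higher number from compound 1 to compound 3 (4.30 log units; beyond the scatter) but that is not the change made here. Compound 3, with phenyl in place of acetamido, reads > 26000 nM as a limit. No step beyond the scatter is therefore expected in this assay for this exchange. The expected step is a number no higher from compound 2 to compound 4 (the limit leaves the size open) and a further limit is the likeliest report. For compound 4 the estimate is 26000 nM with an expected range from 8000 nM to 60000 nM in this assay.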

Compound 4, half-maximal effective concentration: > 26000 nM
Compound 4 was reported as a limit; the forecaster's own chance of this, stated with the estimate: 75%; the middle value lies on the limit itself.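

In this assay, 3-acetylphenyl in place of naphthalen-1-yl gives an at least 20000-fold higher number from compound 1 to compound 4 (4.30 log units; beyond the scatter), so the large step now holds for three different replacements of naphthalen-1-yl, with none of compounds 2, 3 and 4 going against it. The steps from compound 2 and compound 3 to compound 4 cannot be read, and compound 4 shares their limit: the limit of > 26000 nM in this assay, at which 3 of the 4 values shown sit. Acetyl in place of acetamido removes the nitrogen and the hydrogen-bond donor, yet the reading does not come off the limit, so this exchange shows no return towards compound 1.

On these data alone, how far compounds 2, 3 and 4 lie beyond the limit remains open, as does the size of any difference among them. An amine or a carboxylic acid on the same aromatic carbon in place of acetyl would test whether any 3-substituted phenyl comes off this limit.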